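This account rests on a few compounds, and the source may have more. Where it says the series, first, only, none or still open, it means among the compounds named here.

Measured compounds in the series:

- Compound 1, `COC(=O)N[C@H](C(=O)NN(CCC[C@@](O)(Cc1ccccc1)C(=O)N[C@H]1c2ccccc2C[C@H]1O)Cc1ccc(Cl)cc1)C(C)(C)C`. In an ADME assay on MT4 cells (Homo sapiens) for cytotoxicity (a higher number here means that more compound is tolerated, a lower number that less compound is tolerated), compound 1 gives > 10000 nM, which is a limit of the assay and not a number.
- Compound 2, `COC(=O)N[C@H](C(=O)NN(CCC[C@@](O)(Cc1ccccc1)C(=O)N[C@H]1c2ccccc2C[C@H]1O)Cc1ccc(-c2cncnc2)cc1)C(C)(C)C`. In this assay compound 2 gives > 10000 nM, again a limit.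
- Compound 3, `COC(=O)N[C@H](C(=O)NN(CCC[C@@](O)(Cc1ccccc1)C(=O)N[C@H]1c2ccccc2C[C@H]1O)Cc1ccc(-c2nccs2)cc1)C(C)(C)C`. In this assay compound 3 gives > 10000 nM, also a limit.

Compound 3 therefore stands only at a limit, and the two other values sit at the same limit (the limit of > 10000 nM in this assay, at which 3 of the 3 values shown sit). The steps between the measured compounds, a step that the two limits leave unreadable from compound 1 to compound 2, a step that the two limits leave unreadable from compound 1 to compound 3 and a step that the two limits leave unreadable from compound 2 to compound 3, are each unreadable in size and direction.

Compound 4, `COC(=O)N[C@H](C(=O)NN(CCC[C@@](O)(Cc1ccccc1)C(=O)N[C@H]1c2ccccc2C[C@H]1O)Cc1ccc(-c2cn3ccsc3n2)cc1)C(C)(C)C`, is not yet measured in this assay. The change from compound 3 is a group of 8 heavy atoms (5 carbon, 2 nitrogen, 1 sulfur; 2 five-membered aromatic rings with 2 hetero atoms each) in place of a group of 5 heavy atoms (3 carbon, 1 nitrogen, 1 sulfur; one five-membered aromatic ring with 2 hetero atoms), on an aromatic carbon. Within the data shown here, the steps that bear on it are the three swaps of the group on this aromatic carbon, all of which are unreadable, so no size or direction can be taken from them; the expectation is simply that the limit is reached again.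

Compound 4 is expected to give 15000 nM in this assay, estimated between 7000 nM and 40000 nM. The step that the limit leaves unreadable from compound 3 to compound 4 is the expected consequence, most likely read only as a limit.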

Compound 4, half-maximal cytotoxic concentration: > 10000 nM
Compound 4 gave a limit, no number; the forecaster's own chance of this, stated with the estimate: 85%; the middle value does not contradict the limit.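

Among these compounds, no step among compound 1, compound 2, compound 3 and compound 4 can be read in size or direction, as all four stand at one limit and give no number: the limit of > 10000 nM in this assay, at which 4 of the 4 values shown sit. The compounds shown leave open whether any group on this aromatic carbon would give a readable value in this assay.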